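The compounds below may be only part of what the source reports. "The series", "measured", "known", "first", "only" and "open" are said of these compounds alone.

In a functional assay on DU-145 cells (Homo sapiens) for cytotoxicity, read by ELISA, with a stated time of 2 days (a lower number here means a stronger inhibitor, a higher number a weaker inhibitor), compound 3 `Oc1cccc(-c2cc(-c3ccccc3)nc(-c3ccsc3)c2)c1` gives 11700 nM, level with compound 1 `Oc1cccc(-c2cc(-c3ccccc3)cc(-c3ccsc3)n2)c1` at 11700 nM. Compound 2 `Oc1cccc(-c2cc(-c3ccccc3)nc(-c3cccs3)c2)c1` gives 19700 nM, within the scatter of compound 3. The next structure, compound 4 `Oc1cccc(-c2cc(-c3ccccc3)nc(-c3ccncc3)c2)c1`, carries pyridin-4-yl in place of thiophen-3-yl on an aromatic carbon. Among the measured compounds shown here, only one measured step bears on this position, a 1.7-fold lower number from compound 2 to compound 3 (0.23 log units; within the scatter), and it stays within the scatter. For the measured compounds named here, no measured step replaces a five-membered aromatic ring with a six-membered one, so the data point in no direction. No shift beyond the scatter is therefore expected in this assay, and the estimated step is a 1.0-fold higher number from compound 3 to compound 4 (0.01 log units; within the scatter). For compound 4 the estimated value is 12000 nM, with an expected range of 5000 nM to 28000 nM.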

Compound 4, half-maximal inhibitory concentration: 18100 nM
Estimate against measurement, compound 4: 1.5-fold (0.18 log units) below, and the stated range covers the measured number.
By their numbers in this assay, from the lowest: compounds 1, 3, 4 and 2 (each within the scatter of the next).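

Until now, only thiophen-2-yl and thiophen-3-yl had been compared at this position, next to the ring nitrogen. In this assay, pyridin-4-yl gives a 1.5-fold higher number from compound 3 to compound 4 (0.19 log units; within the scatter) and a 1.1-fold lower number from compound 2 to compound 4 (0.04 log units; within the scatter) so a six-membered aromatic ring with nitrogen sits within the scatter of both five-membered rings with sulfur. Nothing measured here offers an explanation for this result. Still open, on these data alone, is whether an amine or a carboxylic acid at this position would shift the number beyond the scatter.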